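Swapping one halogen for another on a simple urea

The source may hold more compounds than are shown below. What is called first, only, known or untested is meant among the compounds shown, and "the series" means these compounds.

Three ureas built on a shared core have been tested in an ADME assay on the whole organism with Oryza sativa as the target, tested at 0.1 uM; a higher number here means a weaker effect of the compound at the concentration tested, a lower number a stronger effect. Compound 1 `C[C@H](NC(=O)Nc1ccccc1F)c1ccccc1` gives 98%. Compound 2 `C[C@@H](NC(=O)Nc1ccc(F)cc1)c1ccccc1` has the same atoms as compound 1 joined differently; the difference between the two cores is not broken down here. Compound 2 gives 98%. Compound 3 `C[C@H](NC(=O)Nc1ccccc1Br)c1ccccc1` gives 101%.

Compound 3 arises from compound 1 by a single change: bromo in place of fluoro on an aromatic carbon. That change made a number 3 percentage points higher from compound 1 to compound 3 (within the scatter), so the read-out of the two compounds is the same within the usual scatter of this kind of measurement.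

Compound 4 `C[C@@H](NC(=O)Nc1ccc(Br)cc1)c1ccccc1` has not yet been measured. It arises from compound 2 by bromo in place of fluoro on an aromatic carbon. In compound 4 the entering group sits para to a large group, whereas in compound 3 it sits ortho to a large group, so the two changes are the same kind of change rather than the same change.

Compound 2 stands level with compound 1 at the digits reported, and the step from compound 1 to compound 3 stayed within the scatter. Given that the only measured example of this kind of change is a number 3 percentage points higher from compound 1 to compound 3 (within the scatter), the step is expected to be a number 2 percentage points higher from compound 2 to compound 4 (within the scatter). Compound 4 is therefore estimated to give 100% in this assay, with the expected range running from 91% to 108%.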

Compound 4, a percentage reported as activity, at one concentration (the size of the read-out at that concentration, not a potency): 100%
Compound 4: middle estimate and measured number agree at the digits printed; low and high end bracket the measured number.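

Replacing fluoro with bromo on an aromatic carbon, para to a large group, gave a number 2 percentage points higher from compound 2 to compound 4 (within the scatter). Set beside the earlier example of the same swap, the new step shows that in this assay the change looks alike on both cores, as far as this read-out can tell: the same change on two cores in this assay, a number 3 percentage points higher (within the scatter) from compound 1 to compound 3 and a number 2 percentage points higher (within the scatter) from compound 2 to compound 4, 1 percentage points apart, within the scatter of two such steps

This does not show that the swap has a dependable effect that can be carried from core to core, since both steps lie within the scatter and neither can be told apart from no change at all, and two cores are too few to support a rule for the whole series.

The compounds shown carry only fluoro or bromo on the aromatic ring, so they leave open whether a group of a different kind in that place, such as an amine, a nitrile or a carboxylic acid, would move the number beyond the scatter. They also leave open whether a longer chain elsewhere on the shared core would do so, and whether any step that clearly exceeded the scatter would carry from one core to the other.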